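The compounds below may be only part of what the source reports. "The series", "measured", "known", "first", "only" and "open" are said of these compounds alone.

Measured compounds in a functional assay for inhibition of sodium/hydrogen exchanger (Oryctolagus cuniculus); a lower number here means a stronger inhibitor, a higher number a weaker inhibitor:
compound 1, `Cc1cc(N2CCC(N)CC2)c(S(C)(=O)=O)cc1C(=O)N=C(N)N`, gives 9.8 nM
compound 2, `Cc1cc(Oc2cncc(Cl)c2)c(S(C)(=O)=O)cc1C(=O)N=C(N)N`, gives 14 nM
compound 3, `CS(=O)(=O)c1cc(C(=O)N=C(N)N)ccc1Oc1cncc(Cl)c1`, gives 75 nM

Compound 3 has the highest number of the three measured. Its core differs from that of compound 2 by the change (hydrogen in place of methyl on an aromatic carbon), and this single change brings a 5.4-fold higher number from compound 2 to compound 3 (0.73 log units; beyond the scatter). Compound 1 and compound 2 share a core and differ by 4-aminopiperidin-1-yl in place of (5-chloropyridin-3-yl)oxy on an aromatic carbon; that replacement gives a 1.4-fold lower number from compound 2 to compound 1 (0.15 log units; within the scatter), so the two values are close to each other.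

The unmeasured compound 4, `CS(=O)(=O)c1cc(C(=O)N=C(N)N)ccc1N1CCC(N)CC1`, stands to compound 3 as compound 1 stands to compound 2: it carries 4-aminopiperidin-1-yl in place of (5-chloropyridin-3-yl)oxy on an aromatic carbon. The surroundings are not identical, since in the pair built on compound 2 the place is also meta to a methyl group, which the core of compound 3 lacks; the change is therefore the same kind of change rather than the same one. Going by the values given here, the only guide to its effect is the earlier pair, where a 1.4-fold lower number from compound 2 to compound 1 (0.15 log units; within the scatter) was a small movement. On that basis the estimate for compound 4 is a step of a 1.4-fold lower number from compound 3 to compound 4 (0.13 log units; within the scatter), resting on the value of compound 3, 75 nM, and on the step of the earlier pair. Compound 4 is therefore expected to give about 55 nM in this assay, within a range from 25 nM to 120 nM.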

Compound 4, half-maximal inhibitory concentration: 160 nM
Beside the measured number, compound 4's estimate is 2.9-fold (0.46 log units) below it, outside the stated range (above it).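

In this assay, the replacement of (5-chloropyridin-3-yl)oxy by 4-aminopiperidin-1-yl does not carry over unchanged to the core without the methyl group, where it brings a 2.1-fold higher number from compound 3 to compound 4 (0.33 log units; beyond the scatter), and its effect differs between the two cores: the same change on two cores in this assay, a 1.4-fold lower number (0.15 log units; within the scatter) from compound 2 to compound 1 and a 2.1-fold higher number (0.33 log units; beyond the scatter) from compound 3 to compound 4, 3.0-fold (0.48 log units) apart, beyond the scatter of two such steps

Seen the other way round, hydrogen in place of methyl costs more when 4-aminopiperidin-1-yl is present, with a 16-fold higher number from compound 1 to compound 4 (1.21 log units; beyond the scatter), and this too differs from the step seen with (5-chloropyridin-3-yl)oxy: the same change on two cores in this assay, a 5.4-fold higher number (0.73 log units; beyond the scatter) from compound 2 to compound 3 and a 16-fold higher number (1.21 log units; beyond the scatter) from compound 1 to compound 4, 3.0-fold (0.48 log units) apart, beyond the scatter of two such steps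

Both comparisons rest on the same four compounds, so they are one finding seen from two sides: the two changes do not act independently here, but this single set neither explains the dependence nor shows that it extends to any other group or core.

The compounds shown leave open whether the dependence on the methyl group requires the amine of the 4-aminopiperidin-1-yl group, which a plain piperidin-1-yl group compared on both cores could test. They also leave open whether it is specific to methyl, or whether an ethyl group or a chlorine atom at that place would give the same pattern.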